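Amide Aryl Swap on a Shared Core: Compound 4 Expected

The compounds below may be only part of what the source reports. "The series", "measured", "known", "first", "only" and "open" are said of these compounds alone.

Of the compounds shown here, three built on one core have been measured in an assay on isolated protein for inhibition of Rho-associated protein kinase 1 (Homo sapiens), read by scintillation counting, radiometric assay and 33P incorporation, with a stated time of 40 min, in the presence of a further agent that is not named here; on this read-out higher numbers stand for weaker inhibition and lower numbers for stronger inhibition. Compound 1 `CC(C)(C)c1ccc(C(=O)Nc2cccc(NC(=O)COc3ccc4c(=O)ccoc4c3)c2)cc1` gives 165 nM, compound 2 `O=C(COc1ccc2c(=O)ccoc2c1)Nc1cccc(NC(=O)c2ccc(Br)cc2)c1` gives 303 nM, and compound 3 `O=C(COc1ccc2c(=O)ccoc2c1)Nc1cccc(NC(=O)c2cccc([N+](=O)[O-])c2)c1` gives 528 nM. Compound 3 therefore stands at the highest number of the three, its nearest neighbour being compound 2, whereas the step of a 3.2-fold higher number from compound 1 to compound 3 (0.51 log units; beyond the scatter) lies beyond the scatter, so compound 3 is the weakest of the set on this read-out.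

Compound 4 `NCc1ccc(C(=O)Nc2cccc(NC(=O)COc3ccc4c(=O)ccoc4c3)c2)cc1` differs from compound 3 by 4-(aminomethyl)phenyl in place of 3-nitrophenyl on a carbonyl carbon. Within the data shown here, the steps that bear on this change are a 3.2-fold higher number from compound 1 to compound 3 (0.51 log units; beyond the scatter) and a 1.7-fold higher number from compound 2 to compound 3 (0.24 log units; within the scatter), both replacements of a 3-nitrophenyl by a 4-substituted phenyl on the same carbonyl carbon, and both ran toward higher numbers when the 3-nitrophenyl entered. Reversing that direction, compound 4 is expected to give a somewhat lower number than compound 3, a step of about a 1.8-fold lower number from compound 3 to compound 4 (0.25 log units; within the scatter), though the aminomethyl group has no measured counterpart here, so the range is wide. The estimate for compound 4 in this assay is 300 nM, between 90 nM and 1000 nM.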

Compound 4, half-maximal inhibitory concentration: 532 nM
Compound 4: the middle estimate sits 1.8-fold (0.25 log units) below what was measured, and the stated range covers the measured number.
By their numbers in this assay, from the lowest: compounds 1, 2, 3 and 4 (each within the scatter of the next, the first and the last beyond it).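

In this assay, the swap of 3-nitrophenyl for 4-(aminomethyl)phenyl on the carbonyl carbon does not separate the two compounds (a 1.0-fold higher number from compound 3 to compound 4 (0.00 log units; within the scatter)), although this single change alters both the substituent and its printed ring position. Among the 4-substituted phenyl amides, aminomethyl in place of bromo stays within the scatter (a 1.8-fold higher number from compound 2 to compound 4 (0.24 log units; within the scatter)), whereas aminomethyl in place of tert-butyl goes beyond it (a 3.2-fold higher number from compound 1 to compound 4 (0.51 log units; beyond the scatter)), so here only compound 1 stands apart from compound 4. Nothing available gives a reason for these steps.

Substituent and ring position change together in this swap. 4-nitrophenyl and 3-(aminomethyl)phenyl would be needed to tell their contributions apart. Going by these compounds, it also remains open how a carboxylic acid or a 2-aminoethyl chain on the same ring would compare with aminomethyl.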